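Swapping an Amide Substituent and Expecting No Cytotoxicity

This account rests on a few compounds, and the source may have more. Where it says the series, first, only, none or still open, it means among the compounds named here.

Compound 1, `O=C(NCC1CCCCC1)c1cccc(/C=C2\CC(=O)N(c3ccccc3)C2=O)c1`, is one of three compounds examined in an ADME assay on NCM460 cells (Homo sapiens) for cytotoxicity, read by MTT assay, with a stated time of 72 h; a higher number here means a weaker inhibitor, a lower number a stronger inhibitor. In this assay compound 1 gives > 100000 nM, which is a limit of the assay rather than a number. Compound 2, `O=C(Nc1ccc(F)cc1)c1cccc(/C=C2\CC(=O)N(c3ccccc3)C2=O)c1`, carries 4-fluorophenyl in place of cyclohexylmethyl on an amide-type nitrogen; in this assay compound 2 gives > 100000 nM, again a limit. Compound 3, `Cc1ccc(N2C(=O)C/C(=C\c3cccc(C(=O)Nc4ccc(Cl)cc4)c3)C2=O)cc1`, gives > 100000 nM in this assay, also a limit. Among the compounds with values here, because every value sits at the limit of > 100000 nM in this assay, at which 3 of the 3 values shown sit, the only step between compounds that differ in one place, a step that the two limits leave unreadable from compound 1 to compound 2, cannot be sized: the two limits hide whatever difference exists.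

Compound 4, `O=C(Nc1ccc(OC(F)F)cc1)c1cccc(/C=C2\CC(=O)N(c3ccccc3)C2=O)c1`, has not yet been measured. Its change from compound 1 is 4-(difluoromethoxy)phenyl in place of cyclohexylmethyl on an amide-type nitrogen. Within the data shown here, this change closely resembles the one behind a step that the two limits leave unreadable from compound 1 to compound 2, where an aromatic ring with a small substituent replaced the same cyclohexylmethyl group and the outcome stayed at the limit. Among the measured compounds shown here, no measured step therefore points to a shift in either direction, and the expectation is a step of no size beyond the scatter, a number no higher from compound 1 to compound 4 (the limit leaves the size open), with the result most probably reported as a limit once more. Compound 4 is accordingly estimated to give about 100000 nM, within a range from 30000 nM to 300000 nM.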

Compound 4, half-maximal inhibitory concentration: > 100000 nM
Compound 4 was reported as a limit (the forecaster's own chance of this, stated with the estimate: 85%); the middle value lies on the limit itself.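

Within the data shown here, no step from compound 1 or compound 2 to compound 4 can be sized, because each value in this assay is a limit of the assay rather than a number: the limit of > 100000 nM in this assay, at which 4 of the 4 values shown sit. The compounds shown leave open how far past that limit each one lies, and whether any amide substituent on the shared core would give a readable number in this assay.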